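The source may report more compounds than this note shows. Statements on the series, on what has been measured and on what is new or still open speak of the compounds shown alone.

In a functional assay on HepG2 cells (Homo sapiens) for antiproliferative activity, read by MTT assay, with a stated time of 48 h (on this read-out lower numbers stand for stronger inhibition and higher numbers for weaker inhibition), compound 1 `Nc1nc(N2CCCC2)sc1C(=O)/C=C/c1ccc(Cl)cc1` gives 27 ug/mL. Compound 2 `Nc1nc(N2CCCCC2)sc1C(=O)/C=C/c1ccc(Cl)cc1` gives 12 ug/mL, the lowest of the three numbers, though compound 3 sits within the scatter of it; the step of a 2.3-fold lower number from compound 1 to compound 2 (0.35 log units; beyond the scatter) lies beyond the scatter. Compound 3 `Nc1nc(N2CCCCC2)sc1C(=O)/C=C/c1ccc(Cl)cc1Cl` gives 22.9 ug/mL, and the step of a 1.9-fold higher number from compound 2 to compound 3 (0.28 log units; within the scatter) stays within the scatter. Compound 4 `Nc1nc(N2CCCCC2)sc1C(=O)/C=C/c1ccc([N+](=O)[O-])cc1` differs from compound 2 by nitro in place of chloro on an aromatic carbon. Neither measured step touches this exchange: one swaps pyrrolidin-1-yl for piperidin-1-yl, the other adds a chloro. The data therefore give no guide to direction, and no step beyond the scatter is expected in this assay. Compound 4 is estimated at 12 ug/mL, within a range from 5 ug/mL to 30 ug/mL, an expected step of no change at the digits printed from compound 2 to compound 4 (within the scatter).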

Compound 4, half-maximal inhibitory concentration: 15.4 ug/mL
The estimate for compound 4 lay 1.3-fold (0.11 log units) below the measured number; the measured number falls inside the stated range.
By their numbers in this assay, from the lowest: compounds 2, 4, 3 and 1 (each within the scatter of the next, the first and the last beyond it).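

In this assay, the exchange of chloro for nitro on the aromatic carbon para to a large group shows a 1.3-fold higher number from compound 2 to compound 4 (0.11 log units; within the scatter). This position therefore accepts a nitro, with three heavy atoms and two hydrogen-bond acceptors, in place of a single chlorine without a step beyond the scatter. Nothing available explains this result.

The compounds shown leave open how an amine or a carboxylic acid would read at this position. They also leave open whether nitro would give a similar reading with the pyrrolidin-1-yl group of compound 1.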